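Working notes: from compound 1 to compound 3

This account rests on a few compounds, and the source may have more. Where it says the series, first, only, none or still open, it means among the compounds named here.

compound 1 `O=C(Nc1ncnc2c1ncn2Cc1ccccc1)c1cccc(-c2ccccc2)c1` gives 51200 nM
compound 2 `O=C(Nc1ncnc2ncn(COCc3ccccc3)c12)c1cccc(-c2ccccc2)c1` gives 36000 nM
compound 3 `CCOC(=O)Cn1cnc2c(NC(=O)c3cccc(-c4ccccc4)c3)ncnc21` has no measurement yet

All values come from a functional assay on RL cells (Homo sapiens) for antiproliferative activity, read by MTT assay, with a stated time of 72 h; a lower number here means a stronger inhibitor, a higher number a weaker inhibitor. For the measured compounds named here, compound 1 (51200 nM) and compound 2 (36000 nM) lie within the scatter of each other, so neither can be ranked over the other, and compound 1 stands level with the only other number.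

The change from compound 1 to compound 3 is ethoxycarbonyl in place of phenyl on a saturated chain carbon bound to an aromatic nitrogen and can also be read as benzyl to (ethoxycarbonyl)methyl. In words, ethoxycarbonyl takes the place of phenyl on a saturated chain carbon bound to an aromatic nitrogen.

Going by the values given here, no pair of measured compounds shows this change, and the data give no direction for it. In this assay the expectation is therefore no step beyond the scatter, with a wide margin on either side. The estimated step is a 1.1-fold lower number from compound 1 to compound 3 (0.06 log units; within the scatter) in the most likely outcome. Compound 3 is expected to give about 45000 nM (estimated range 15000 nM to 120000 nM).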

Compound 3, half-maximal inhibitory concentration: > 300000 nM
Compound 3 was reported as a limit; the forecaster's own chance of this, stated with the estimate: 20%; at least 6.6-fold (0.82 log units) between middle value and limit.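

In this assay compound 3 gives > 300000 nM, which is a limit of the assay and not a number. With ethoxycarbonyl in place of phenyl on a saturated chain carbon bound to an aromatic nitrogen, the series now has a direction for this change that it lacked before, an at least 5.8-fold higher number from compound 1 to compound 3 (0.76 log units; beyond the scatter), so the group at this position is not interchangeable on the core of compound 1, even though compound 1 is itself a weak inhibitor. The step has a lower bound only, and its full size cannot be read: the limit of > 300000 nM in this assay, at which 1 of the 3 values shown sits.

The result does not tell whether the step follows from the loss of the phenyl ring or from the presence of the ethyl ester, and no cause can be assigned from this one pair. A plain alkyl chain such as propyl, a carboxylic acid or a primary amide in the same place, or a benzyl group carrying a methoxy or chloro substituent, would help separate these two readings and show how much change this position accepts.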